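Lengthening the Ketone Side Chain from Isopropyl to Isobutyl

The source may report more compounds than this note shows. Statements on the series, on what has been measured and on what is new or still open speak of the compounds shown alone.

Compound 3 `Cc1c(OCCCCOc2ccc(F)c(C(=O)O)c2)ccc(C(=O)C(C)C)c1O` was tested in an assay on HEK293 cells for positive allosteric modulation of metabotropic glutamate receptor 3 (Rattus norvegicus), read by thallium flux, with a stated time of 2.5 min; a higher number here means that more compound is needed for the effect, a lower number that less compound is needed. In this assay compound 3 reaches only > 10000 nM, which is a limit of the assay and not a number. Two further compounds share its core. Compound 1 `Cc1c(OCCCCOc2ccc(C(=O)O)cc2F)ccc(C(=O)CC(C)C)c1O` gives 1420 nM in this assay. Compound 2 `Cc1c(OCCCCOc2ccc(F)c(C(=O)O)c2)ccc(C(=O)CC(C)C)c1C` has "not determined" (no result reported) in this assay. Among the three entries, compound 3 is therefore one of those without a single number (the limit of > 10000 nM in this assay, at which 1 of the 3 values shown sits).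

Compound 4 `Cc1c(OCCCCOc2ccc(F)c(C(=O)O)c2)ccc(C(=O)CC(C)C)c1O` differs from compound 3 in one place: isobutyl in place of isopropyl on a carbonyl carbon. Read one bond further out, an isopropylcarbonyl becomes an isobutylcarbonyl. Among the measured compounds shown here, no measured pair shows this change on its own, so its size cannot be taken from the data. Compound 1, which also carries an isobutyl on its carbonyl carbon, gives 1420 nM. On that basis compound 4 is estimated at 3000 nM, with a range from 800 nM to 15000 nM. This estimate implies a step of an at least 3.3-fold lower number from compound 3 to compound 4 (0.52 log units; beyond the scatter), expected to be beyond the usual scatter and in the direction of less compound needed.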

Compound 4, half-maximal effective concentration: 920 nM
For compound 4 the middle estimate is 3.3-fold (0.51 log units) above the measured one; the range from low to high includes it.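

The isobutyl in place of isopropyl on a carbonyl carbon gives an at least 10-fold lower number from compound 3 to compound 4 (1.03 log units; beyond the scatter), so this side chain, small as the swap is, has a large effect on how much compound is needed. Compound 3 holds only a limit of the assay and not a number, so the true size of this step stays unknown: the limit of > 10000 nM in this assay, at which 1 of the 4 values shown sits.

With isobutyl kept on the carbonyl carbon, 3-carboxy-4-fluorophenyl in place of 4-carboxy-2-fluorophenyl gives a 1.5-fold lower number from compound 1 to compound 4 (0.19 log units; within the scatter), so the two aromatic groups cannot be told apart in this assay.

On these data alone, only isopropyl and isobutyl appear on this carbonyl carbon, so it stays open whether a longer chain such as n-pentyl, or a ring such as cyclohexyl, would lower the number further. Compound 2 has no result in this assay and adds nothing to this question.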